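This account rests on a few compounds, and the source may have more. Where it says the series, first, only, none or still open, it means among the compounds named here.

Working notes on the series. Compound 1 `CCO[C@@H]1O[C@H](CNC(=O)c2ccc(S(N)(=O)=O)cc2)[C@@H](O)[C@H](O)[C@H]1O` gives 59.5 h in an ADME assay on microsomes from liver (Mus musculus) for metabolic stability; a higher number here means that the compound lasts longer, a lower number that the compound disappears faster. Compound 3 `CCCO[C@@H]1O[C@H](CNC(=O)c2ccc(S(N)(=O)=O)cc2)[C@@H](O)[C@H](O)[C@H]1O` gives 60 h and compound 2 `CCO[C@@H]1O[C@H](CNC(=O)c2ccc(S(N)(=O)=O)cc2)[C@@H](O)[C@H](O)[C@H]1N` gives 58.6 h, so compound 1 stands among three numbers that all lie within the scatter of one another. The two measured steps are a 1.0-fold lower number from compound 1 to compound 2 (0.01 log units; within the scatter) and a 1.0-fold higher number from compound 1 to compound 3 (0.00 log units; within the scatter); neither is beyond the scatter. Compound 4 `CCO[C@@H]1O[C@H](CNC(=O)c2ccc(S(N)(=O)=O)cc2)[C@@H](O)[C@H](O)[C@@H]1O` differs from compound 1 in this way: the two compounds have the same atoms and bonds and differ only in configuration as drawn: 1 of 5 stereo elements differ; a stereocentre at a saturated ring carbon is drawn R in compound 1 and S in compound 4. Within the data shown here, no measured step changes a configuration, so none bears on it directly; the measured steps only show that small changes at the ring and the chain left this assay unchanged. A step within the scatter is therefore expected, a 1.0-fold lower number from compound 1 to compound 4 (0.00 log units; within the scatter). Compound 4 is estimated at 59 h, with a range from 35 h to 95 h.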

Compound 4, half-life: 61.6 h
For compound 4 the middle estimate is 1.0-fold (0.02 log units) below the measured one; low and high end bracket the measured number.
By their numbers in this assay, from the lowest: compounds 2, 1, 3 and 4 (each within the scatter of the next).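

Drawing this saturated ring carbon S instead of R gives a 1.0-fold higher number from compound 1 to compound 4 (0.02 log units; within the scatter) in this assay. Among these compounds, the earlier steps changed groups only, so this is the first reading on configuration, and it isolates that single change: the fact that compounds 1 and 4 differ only in the configuration as drawn. At this stereocentre, configuration therefore leaves the number within the scatter in this assay.

As far as these compounds go, whether a carboxylic acid or a longer chain at this ring carbon would also stay within the scatter remains open. The same holds for changes of configuration at the other stereo elements.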